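This account rests on a few compounds, and the source may have more. Where it says the series, first, only, none or still open, it means among the compounds named here.

Measured compounds:
compound 1 `Cc1n[nH]c2ccc(-c3nc4cnc(N5CCN(C)CC5)cn4c3Nc3cccc(Cl)c3)cc12` gives 0%
compound 2 `Cc1n[nH]c2ccc(-c3nc4cnc(N5CCC(C)CC5)cn4c3Nc3ccc(Cl)cc3)cc12` gives 28%

Both measurements come from a functional assay on MV4-11 cells (Homo sapiens) for inhibition, with a stated time of 120 h, tested at 10 uM; on this read-out lower numbers stand for less inhibition and higher numbers for more inhibition at the one concentration tested (going by the name of the read-out). Compound 1 stands lowest of the two numbers; its nearest neighbour, compound 2, is higher by a margin beyond the usual scatter. For the measured compounds named here, no pair of measured compounds differs in a single place, so no measured step is available to guide the next change.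

Compound 3 `Cc1n[nH]c2ccc(-c3nc4cnc(N5CCN(C)CC5)cn4c3Nc3ccccc3)cc12` is the unmeasured analogue of compound 1. The structural difference is hydrogen in place of chloro on an aromatic carbon; put another way, the 3-chlorophenyl becomes phenyl, the (3-chlorophenyl)amino becomes anilino. The shared core and the remaining groups of compound 1 are kept.

With compound 1 at 0% in this assay, the expectation is a step from compound 1 to compound 3 of a number 5 percentage points higher from compound 1 to compound 3 (within the scatter), which is within the scatter and in no clear direction. Compound 3 is therefore estimated at 5%, with a range from -10% to 25%.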

Compound 3, a percentage reported as inhibition, at one concentration (the size of the read-out at that concentration, not a potency): 0%
Beside the measured number, compound 3's estimate is 5 percentage points above it; the measured number falls inside the stated range.
By their numbers in this assay, from the lowest: compounds 1 and 3 (each within the scatter of the next); then compound 2.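

In this assay, for the compounds shown here, going from 3-chlorophenyl to phenyl gives no change at the digits printed from compound 1 to compound 3 (within the scatter), the first step that differs in one place. On the core of compound 1, the chloro at this position therefore makes no readable difference, but compound 3 at 0% shows no inhibition, as does compound 1, so the step has no measurable inhibition to lose. Nothing on hand explains this reading.

Open, from the compounds shown here alone, is whether the chloro matters on a compound with measurable inhibition, and whether a methoxy, a fluoro or an amine at this place would lift the reading. Compound 2 differs from compound 1 in more than one place, so its higher number cannot be assigned to any single change.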